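The source may hold more compounds than are shown below. What is called first, only, known or untested is meant among the compounds shown, and "the series" means these compounds.

Compound 1 `CC1CCN(c2c(S(=O)(=O)c3cccc(C#N)c3)cnc3cc(F)ccc23)CC1` gives 92% in an assay on isolated protein for displacement of a labelled ligand from metabotropic glutamate receptor 5 (Homo sapiens), with a stated time of 60 min, tested at 1 uM (on this read-out lower numbers stand for less inhibition and higher numbers for more inhibition at the one concentration tested (going by the name of the read-out)), and so shows the higher of the two numbers at hand, yet its only companion, compound 2 `CC1CCN(c2c(S(=O)(=O)c3ccc(C#N)cc3)cnc3cc(F)ccc23)CC1`, gives 83% in this assay, and the step of a number 9 percentage points lower from compound 1 to compound 2 (within the scatter) lies within the scatter, so the two compounds cannot be told apart on this read-out. Compound 3 `COCC1CCN(c2c(S(=O)(=O)c3cccc(C#N)c3)cnc3cc(F)ccc23)CC1` has not yet been measured. It differs from compound 1 by methoxy in place of hydrogen on a saturated chain carbon bound to a saturated ring carbon. Going by the values given here, the one measured step concerns the cyanophenyl on the sulfonyl sulfur and leaves the methylpiperidine side of the shared core untouched, so no measured step bears directly on the change from methyl to methoxymethyl. Among the compounds with values here, a methoxy added in place of hydrogen on a saturated chain carbon is a small change, and with no step of its kind in the data the expectation is for no step beyond the scatter in this assay; compound 3 is therefore expected to give about 86%, with a range from 70% to 97%. That corresponds to an expected step of a number 6 percentage points lower from compound 1 to compound 3 (within the scatter).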

Compound 3, a percentage reported as inhibition, at one concentration (the size of the read-out at that concentration, not a potency): 91%
Estimate against measurement, compound 3: 5 percentage points below; the measured number falls inside the stated range.
By their numbers in this assay, from the lowest: compounds 2, 3 and 1 (each within the scatter of the next).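

Going by these compounds alone, the step of a number 1 percentage points lower from compound 1 to compound 3 (within the scatter) in this assay is the first measured at the 4-methylpiperidin-1-yl group, since the earlier pair differed only in the cyanophenyl on the sulfonyl sulfur. It shows that methoxy in place of hydrogen on a saturated chain carbon bound to a saturated ring carbon, which turns methyl into methoxymethyl, brings no step beyond the scatter, so compound 1 and compound 3 cannot be told apart on this read-out. The material at hand offers no independent finding that would account for this outcome.

The compounds shown leave open whether the same change would read alike on the 4-cyanophenyl compound 2, and whether compound 1 and compound 3 would also stay together in a full concentration series rather than at the one concentration tested. They also leave open how this position would read with an amine, a carboxylic acid or a longer ether chain in place of the methoxymethyl.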